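The source may report more compounds than this note shows. Statements on the series, on what has been measured and on what is new or still open speak of the compounds shown alone.

- compound 1 `COC(=O)CN(C)Cc1c(OC)cc(OC)c(C(=O)/C=C/c2ccccc2Cl)c1O` gives 7200 nM
- compound 2 `COc1cc(OC)c(C(=O)/C=C/c2ccccc2Cl)c(O)c1CN1CCCC1` gives 3100 nM
- compound 3 `CCN(C)Cc1c(OC)cc(OC)c(C(=O)/C=C/c2ccccc2Cl)c1O` gives 3 nM

In a functional assay on PC-3 cells (Homo sapiens) for antiproliferative activity, with a stated time of 72 h (on this read-out higher numbers stand for weaker inhibition and lower numbers for stronger inhibition), compound 3 has the lowest number of the three, meaning the strongest inhibition. Compound 4 `COc1cc(OC)c(C(=O)/C=C/c2ccccc2Cl)c(O)c1CN(C)CCCN(C)C` keeps the shared core but alters the amine chain: (dimethylamino)methyl in place of hydrogen on a saturated chain carbon, two bonds along the chain from an amine nitrogen. Among the measured compounds shown here, two measured steps bear on this. The nearest is a change on the same chain, a 2400-fold lower number from compound 1 to compound 3 (3.38 log units; beyond the scatter), and the other swaps the whole amine, a 1000-fold lower number from compound 2 to compound 3 (3.01 log units; beyond the scatter). For the measured compounds named here, both are large, so the low number of compound 3 looks easily lost, although no measured compound carries this new group. A large upward move is therefore expected, estimated as a 130-fold higher number from compound 3 to compound 4 (2.12 log units; beyond the scatter) here. Compound 4 is expected near 400 nM, within a range from 20 nM to 6000 nM for this estimate.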

Compound 4, half-maximal inhibitory concentration: 14500 nM
The estimate for compound 4 lay 36-fold (1.56 log units) below the measured number; the whole stated range lies below it.
By their numbers in this assay, from the lowest: compound 3; then compound 2; then compounds 1 and 4 (each within the scatter of the next).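

Putting 3-(dimethylamino)propyl in place of ethyl on the amine erases the low number of compound 3 in this assay (a 4800-fold higher number from compound 3 to compound 4 (3.68 log units; beyond the scatter)). The result sits close to the other changed amines (a 4.7-fold higher number from compound 2 to compound 4 (0.67 log units; beyond the scatter); a 2.0-fold higher number from compound 1 to compound 4 (0.30 log units; within the scatter)), so among these four compounds only the ethyl(methyl)amino group of compound 3 gives a low number. Nothing available here explains this loss. As far as these compounds go, what stays open is whether the added length or the terminal dimethylamino group matters more. A plain propyl chain or a 3-hydroxypropyl chain on that nitrogen would separate the two.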